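The compounds below may be only part of what the source reports. "The series", "measured", "known", "first", "only" and "open" are said of these compounds alone.

Going by the values given here, compound 1 `CC(Sc1nc2c(cnn2C)c(=O)n1-c1ccccc1)c1ccccn1` is the first of three measured compounds; in an assay on PEO1 cells for inhibition of Retinaldehyde dehydrogenase 3 (Homo sapiens), read by flow cytometry, with a stated time of 30 min, tested at 1 uM (on this read-out lower numbers stand for less inhibition and higher numbers for more inhibition at the one concentration tested (going by the name of the read-out)), compound 1 gives 97%. Compound 3 `CC(Sc1nc2c(cnn2C)c(=O)n1-c1ccccc1)c1cccnc1` carries the change pyridin-3-yl in place of pyridin-2-yl on a saturated chain carbon bound to a saturated chain carbon and a sulfur relative to compound 1, and in this assay compound 3 gives 95%. The step that this change made, a number 2 percentage points lower from compound 1 to compound 3 (within the scatter), is small. Compound 2 `CC(Sc1nc2nn(C3COC3)cc2c(=O)n1-c1ccccc1)c1ccccn1` rests on a different core; the difference between the core of compound 1 and the core of compound 2 is not broken down here. In this assay compound 2 gives 99%, a number that sits together with those of compound 1 and compound 3 inside the usual scatter.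

Compound 4 `CC(Sc1nc2nn(C3COC3)cc2c(=O)n1-c1ccccc1)c1cccnc1` has not yet been measured. It differs from compound 2 by the change (pyridin-3-yl in place of pyridin-2-yl on a saturated chain carbon bound to a saturated chain carbon and a sulfur), the same change that was made from compound 1 to compound 3, occurring twice among these compounds. Because that earlier step was a number 2 percentage points lower from compound 1 to compound 3 (within the scatter), the step from compound 2 to compound 4 in this assay is expected to be a number 2 percentage points lower from compound 2 to compound 4 (within the scatter). Compound 4 is therefore estimated at 97%, expected to lie between 90% and 100%.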

Compound 4, a percentage reported as inhibition, at one concentration (the size of the read-out at that concentration, not a potency) in the Retinaldehyde dehydrogenase 3 assay: 99%
Compound 4: the middle estimate sits 2 percentage points below what was measured; the range from low to high includes it.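

In the Retinaldehyde dehydrogenase 3 assay the change from pyridin-2-yl to pyridin-3-yl on the core of compound 2 gives no change at the digits printed from compound 2 to compound 4 (within the scatter), and set beside the earlier step on the core of compound 1, it carries over without a visible difference: the same change on two cores in the Retinaldehyde dehydrogenase 3 assay, a number 2 percentage points lower (within the scatter) from compound 1 to compound 3 and no change at the digits printed (within the scatter) from compound 2 to compound 4, 2 percentage points apart, within the scatter of two such steps. Going by these compounds alone, this agreement rests on only two cores and on readings at a single concentration, so it gives no potency for any compound and cannot show whether a difference would appear at lower concentrations. In a physicochemical assay for solubility, using the shake flask method, in phosphate buffer, with a stated time of 24 h, at pH 7.4 (on this read-out higher numbers stand for higher solubility and lower numbers for lower solubility), seen here on the core of compound 2 alone, compound 2 gives 60000 nM and compound 4 gives 189000 nM, and the same change separates the pair: the measured solubility of compound 2, 60000 nM, and of compound 4, 189000 nM, a 3.2-fold higher number (0.50 log units; beyond the scatter).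

Going by these compounds, whether this solubility step recurs on the core of compound 1 remains open. Also open, on these data alone, is how pyridin-4-yl or a plain phenyl in place of the pyridine ring, or an amine or a carboxylic acid on that ring, would read in either assay.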